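The source may report more compounds than this note shows. Statements on the series, on what has been measured and on what is new or still open speak of the compounds shown alone.

Working notes on the series. Compound 1 `CCCc1nc(-c2ccccc2)c(CNCCN2CCN(c3ccc(Cl)cc3)CC2)o1`, compound 2 `CCCc1nc(-c2ccccc2)c(CNCCN2CCN(c3ccccc3C)CC2)o1` and compound 3 `CCCc1nc(-c2ccccc2)c(CNCCCN2CCN(c3ccccc3C)CC2)o1` are measured; compound 4 `CCCc1nc(-c2ccccc2)c(CNCCCN2CCN(c3ccc(Cl)cc3)CC2)o1` is not. In an assay on HEK293 cells for inhibition of Voltage-dependent T-type calcium channel subunit alpha-1G (Homo sapiens), read by patch clamp (a lower number here means a stronger inhibitor, a higher number a weaker inhibitor), compound 1 gives 2820 nM. In this assay compound 2 gives 4300 nM, and compound 3 gives 8750 nM, the highest of the three numbers, with compound 2 nearest and compound 1 furthest, both beyond the scatter.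

The change from compound 2 to compound 1 is 4-chlorophenyl in place of 2-methylphenyl on an amine nitrogen in a ring. It made a step of a 1.5-fold lower number from compound 2 to compound 1 (0.18 log units; within the scatter). How the core of compound 2 differs from that of compound 3 is not broken down here.

The change from compound 3 to compound 4 is 4-chlorophenyl in place of 2-methylphenyl on an amine nitrogen in a ring, the same change at the same place. Next to the earlier step of a 1.5-fold lower number from compound 2 to compound 1 (0.18 log units; within the scatter), the expected step is a 1.5-fold lower number from compound 3 to compound 4 (0.18 log units; within the scatter). This expectation rests on a single pair, because only a 1.5-fold lower number from compound 2 to compound 1 (0.18 log units; within the scatter) shows this change in the series, and it stayed within the scatter. For compound 4 the estimated value is 5800 nM, expected to lie between 2500 nM and 13000 nM.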

Compound 4, half-maximal inhibitory concentration: 1310 nM
Compound 4: middle estimate off by 4.4-fold (0.65 log units), on the high side; the measured number lies below the stated range.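

On the core of compound 3, 4-chlorophenyl in place of 2-methylphenyl gave a 6.7-fold lower number from compound 3 to compound 4 (0.82 log units; beyond the scatter) in this assay, on an amine nitrogen in a ring, the same place as in the earlier pair. The size of the step did not carry from one core to the other: the same change on two cores in this assay, a 1.5-fold lower number (0.18 log units; within the scatter) from compound 2 to compound 1 and a 6.7-fold lower number (0.82 log units; beyond the scatter) from compound 3 to compound 4, 4.4-fold (0.64 log units) apart, beyond the scatter of two such steps. The number is lower on both cores, but the step on the core of compound 2 stays within the scatter, so these two pairs show that the size of this change differs with the core; they do not show why it differs, and they give no rule for any further core.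

The compounds shown leave open whether a longer chain than that of compound 3 would give a step of similar size or a different one. Also open, as far as these compounds go, is how a plain phenyl group on the same ring nitrogen would compare with 4-chlorophenyl and 2-methylphenyl on either core.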